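The source may hold more compounds than are shown below. What is called first, only, known or untested is meant among the compounds shown, and "the series" means these compounds.

Measured in a physicochemical assay for solubility, read by HPLC, in phosphate buffer, at pH 6.8; on this read-out lower numbers stand for lower solubility and higher numbers for higher solubility:
- Compound 1 `CC[C@@H]1CC[C@@H](C(=O)N2CCN(C)CC2)N1C(=O)C1=C(C(C)C)N2C(=N[C@@](C)(c3ccc(Cl)cc3)[C@H]2c2ccc(Cl)cc2)S1`: 13 ug/mL
- Compound 2 `CC(=O)N1CCN(C(=O)[C@@H]2CC[C@@H](C)N2C(=O)C2=C(C(C)C)N3C(=N[C@@](C)(c4ccc(Cl)cc4)[C@H]3c3ccc(Cl)cc3)S2)C[C@H]1C`: 72 ug/mL
- Compound 3 `CC(=O)N1CCN(C(=O)[C@@H]2CC[C@@H](C)N2C(=O)C2=C(C(C)C)N3C(=N[C@@](C)(c4ccc(Cl)cc4)[C@H]3c3ccc(Cl)cc3)S2)C[C@@H]1C`: 75 ug/mL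

Compound 1 has the lowest number of the three, and its gap to each of the others lies beyond the scatter. Compound 4 `CC[C@@H]1CC[C@@H](C(=O)N2CCN(C(C)=O)[C@@H](C)C2)N1C(=O)C1=C(C(C)C)N2C(=N[C@@](C)(c3ccc(Cl)cc3)[C@H]2c2ccc(Cl)cc2)S1` keeps the rest of compound 1 and exchanges one group: a group of 10 heavy atoms (7 carbon, 2 nitrogen, 1 oxygen; one six-membered non-aromatic ring with 2 hetero atoms) in place of a group of 7 heavy atoms (5 carbon, 2 nitrogen; one six-membered non-aromatic ring with 2 hetero atoms), on a carbonyl carbon. The entering group also appears in compound 2 and compound 3, although neither is identical to compound 4 elsewhere.

Among the compounds with values here, the only measured step is a 1.0-fold higher number from compound 2 to compound 3 (0.02 log units; within the scatter). It reflects (the fact that compounds 2 and 3 differ only in the configuration as drawn), so it suggests that configuration at that saturated ring carbon need not shift the number much. Within the data shown here, no measured step isolates the group exchange itself, so the best guide is the pair of values, with compound 2 at 72 ug/mL and compound 3 at 75 ug/mL. A rise beyond the scatter is therefore expected, though probably short of those two values. The expected change in this assay is a 3.8-fold higher number from compound 1 to compound 4 (0.59 log units; beyond the scatter). For compound 4 the estimated value is 50 ug/mL, with an expected range from 20 ug/mL to 120 ug/mL.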

Compound 4, solubility: 24 ug/mL
For compound 4 the middle estimate is 2.1-fold (0.32 log units) above the measured one, and the stated range covers the measured number.
By their numbers in this assay, from the lowest: compounds 1 and 4 (each within the scatter of the next); then compounds 2 and 3 (each within the scatter of the next).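

In this assay, the exchange on the carbonyl carbon, with 4-methylpiperazin-1-yl leaving, gives a 1.8-fold higher number from compound 1 to compound 4 (0.27 log units; within the scatter), so this exchange alone does not clearly separate the two compounds. The values of compound 2 and compound 3 did not carry over to compound 4: methyl in place of hydrogen on a saturated chain carbon bound to a saturated ring carbon gives a 3.1-fold lower number from compound 3 to compound 4 (0.49 log units; beyond the scatter), and of the two new steps only this small addition lies beyond the scatter. Nothing measured here accounts for either step.

As far as these compounds go, it remains open whether a morpholine ring or a piperazine carrying a carboxylic acid, placed on the same carbonyl carbon, would move the number beyond the scatter from compound 1. Within the data shown here, it is also open whether a longer chain in place of the one in compound 4 would continue the drop seen from compound 3.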